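A few compounds are considered here, and "the series" means these few. Any claim that something is new, unique, unknown or untested is made for them only; others in the source may bear on it.

Measured so far in a physicochemical assay for lipophilicity, read by HPLC, at pH 7.5; on this read-out higher numbers stand for higher lipophilicity and lower numbers for lower lipophilicity:
- compound 1 `CC[C@@H](Nc1c(C#N)c(-c2ccc(-c3ccccc3F)cc2)nc2cnccc12)C(N)=O` gives 2.7
- compound 2 `CC[C@@H](Nc1c(C#N)c(-c2ccc(-c3cccnc3C)cc2)nc2cnccc12)C(N)=O` gives 1.9

Within the data shown here, compound 2 stands lowest of the two numbers in this assay; its nearest neighbour is compound 1, and the one measured step, a number 0.80 log units lower from compound 1 to compound 2 (beyond the scatter), separates them.

Compound 3 `CC[C@@H](Nc1c(C#N)c(-c2ccc(-c3ccccc3C(C)C)cc2)nc2cnccc12)C(N)=O` is not yet measured. Its change from compound 2 is 2-isopropylphenyl in place of 2-methylpyridin-3-yl on an aromatic carbon.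

Among the measured compounds shown here, only one measured step bears on this change, and it does so in reverse: a number 0.80 log units lower from compound 1 to compound 2 (beyond the scatter) covered the introduction of the 2-methylpyridin-3-yl group in place of 2-fluorophenyl. Compound 3 undoes that ring exchange, returning to a six-membered aromatic ring of carbon only, and in addition carries 2-isopropylphenyl rather than 2-fluorophenyl. Because a number 0.80 log units lower from compound 1 to compound 2 (beyond the scatter) was beyond the scatter, the return to an all-carbon ring in compound 3 is expected to recover that much at least, and the further change is expected to add to it. The step is therefore estimated as a number 1.70 log units higher from compound 2 to compound 3 (beyond the scatter), upward and beyond the scatter. Compound 3 is expected to give 3.6, within a range of 3 to 4.2.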

Compound 3, distribution coefficient: 3.5
Estimate against measurement, compound 3: 0.10 log units above, within the range that was stated.
By their numbers in this assay, from the lowest: compound 2; then compound 1; then compound 3.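

In this assay, this position spans more than the first pair showed: 2-isopropylphenyl in place of 2-methylpyridin-3-yl gives a number 1.60 log units higher from compound 2 to compound 3 (beyond the scatter), a large step in which a ring of carbon only with 9 heavy atoms replaces a ring with one hetero atom and 7 heavy atoms. With the ring of carbon kept, isopropyl in place of fluoro alone gives a number 0.80 log units higher from compound 1 to compound 3 (beyond the scatter), so the read-out at this place does not depend only on the exchange of ring type. Nothing measured here speaks to the reason for either step.

The large step combines two differences, the ring nitrogen and the alkyl group, and the compounds shown do not separate them; a 2-methylphenyl group, which keeps the methyl of compound 2 on a ring of carbon only, would differ from compound 2 in the ring nitrogen alone. Also open, as far as these compounds go, is how far the read-out in this assay would follow other groups on that ring, such as a tert-butyl group, an amine or a carboxylic acid.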